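Benzyl ether exchange carried across two cores

This account rests on a few compounds, and the source may have more. Where it says the series, first, only, none or still open, it means among the compounds named here.

Compound 1 `Cc1ccc(NC(=S)NC(=O)c2ccc(OCc3ccccc3F)cc2)cc1-c1nc2ccccc2[nH]1` and compound 2 `Cc1ccc(COc2ccc(C(=O)NC(=S)Nc3ccc(C)c(-c4nc5ccccc5[nH]4)c3)cc2)cc1` share one core; compound 3 `O=C(NC(=O)c1ccc(OCc2ccccc2F)cc1)Nc1ccc(Cl)c(-c2nc3ccccc3[nH]2)c1` and compound 4 `Cc1ccc(COc2ccc(C(=O)NC(=O)Nc3ccc(Cl)c(-c4nc5ccccc5[nH]4)c3)cc2)cc1` share another. The difference between the two cores is not broken down here. In a functional assay on HT-29 cells (Homo sapiens) for inhibition, read by MTT assay, with a stated time of 48 h (on this read-out higher numbers stand for weaker inhibition and lower numbers for stronger inhibition), compound 1 gives 1870 nM, and compound 2 gives 14200 nM. The change between them is 4-methylphenyl in place of 2-fluorophenyl on a saturated chain carbon bound to an oxygen on an aromatic ring, and it produced a 7.6-fold higher number from compound 1 to compound 2 (0.88 log units; beyond the scatter). In this assay compound 3 gives 590 nM, the lowest of the three numbers. Compound 4 carries the same change on the second core: 4-methylphenyl in place of 2-fluorophenyl on a saturated chain carbon bound to an oxygen on an aromatic ring. With a single earlier instance of this change, the step from compound 3 to compound 4 is expected to be of similar size, a 6.8-fold higher number from compound 3 to compound 4 (0.83 log units; beyond the scatter), because the earlier step was a 7.6-fold higher number from compound 1 to compound 2 (0.88 log units; beyond the scatter). Compound 4 is therefore estimated at 4000 nM in this assay, with a range from 1500 nM to 12000 nM.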

Compound 4, half-maximal inhibitory concentration: 2950 nM
For compound 4 the middle estimate is 1.4-fold (0.13 log units) above the measured one; measured number inside the range.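

In this assay, the same change on the second core gives a 5.0-fold higher number from compound 3 to compound 4 (0.70 log units; beyond the scatter), in the same direction as on the first core. The two steps agree in size: the same change on two cores in this assay, a 7.6-fold higher number (0.88 log units; beyond the scatter) from compound 1 to compound 2 and a 5.0-fold higher number (0.70 log units; beyond the scatter) from compound 3 to compound 4, 1.5-fold (0.18 log units) apart, within the scatter of two such steps. Among the compounds shown here, this shows that the change from 2-fluorophenyl to 4-methylphenyl carried over from the core of compound 1 to the core of compound 3 in this assay, but with only two pairs it does not show that the step would hold on any further core, nor does it give a reason for the step.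

The compounds shown leave open how a plain phenyl would read at this place, which would help separate the loss of the fluorine from the gain of the methyl. Going by these compounds, how a pyridine ring or a carboxylic acid-bearing phenyl would read there also remains open.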